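The compounds below may be only part of what the source reports. "The series", "measured", "known", "first", "only" and "open" are said of these compounds alone.

Compound 1 `CCCCC(=O)NC(=S)Nc1nc2cc(Br)ccc2s1`: 45700 nM in a functional assay on MCF7 cells (Homo sapiens) for cytotoxicity, read by MTT assay, with a stated time of 24 h; a lower number here means a stronger inhibitor, a higher number a weaker inhibitor
Compound 2 `CCCCC(=O)NC(=S)Nc1nc2ccccc2s1`: 36600 nM in this assay
Compound 3 `O=C(NC(=S)Nc1nc2cc(Br)ccc2s1)c1ccc([N+](=O)[O-])cc1`: 32400 nM in this assay

Compound 4 `O=C(NC(=S)Nc1nc2ccccc2s1)c1ccc([N+](=O)[O-])cc1` has not yet been measured. Compound 4 is reached from compound 3 by hydrogen in place of bromo on an aromatic carbon. The same kind of change leads from compound 1 to compound 2, namely (hydrogen in place of bromo on an aromatic carbon), and there it gave a 1.2-fold lower number from compound 1 to compound 2 (0.10 log units; within the scatter). The difference between the core of compound 1 and the core of compound 3 is not broken down here; what their two values show is that they sit within the usual scatter of each other. Because the earlier step of a 1.2-fold lower number from compound 1 to compound 2 (0.10 log units; within the scatter) was small, a similarly small step is expected from compound 3 to compound 4, estimated as a 1.1-fold lower number from compound 3 to compound 4 (0.05 log units; within the scatter). Compound 4 is therefore expected to give about 29000 nM in this assay, most likely between 15000 nM and 58000 nM.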

Compound 4, half-maximal inhibitory concentration: 33800 nM
The estimate for compound 4 lay 1.2-fold (0.07 log units) below the measured number; the range from low to high includes it.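

Replacing bromo with hydrogen gave a 1.0-fold higher number from compound 3 to compound 4 (0.02 log units; within the scatter) in this assay, so this second core also shows no clear difference. The two steps agree with each other: the same change on two cores in this assay, a 1.2-fold lower number (0.10 log units; within the scatter) from compound 1 to compound 2 and a 1.0-fold higher number (0.02 log units; within the scatter) from compound 3 to compound 4, 1.3-fold (0.11 log units) apart, within the scatter of two such steps. This shows that the change behaved alike on the two cores shown, but both steps lie within the scatter, so it shows only that a small step carried over and says nothing about other cores or about a step large enough to stand out.

From the compounds shown here alone, only bromo and hydrogen appear at this place, so it remains open whether a methoxy group or an amine there would give a clearly different number. Going by these compounds, a longer chain on the carbonyl also remains open.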